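The compounds below may be only part of what the source reports. "The series", "measured", "known", "first", "only" and "open" are said of these compounds alone.

Measured so far:
- compound 1 `O=C(Nc1ccc(-c2cscn2)cc1)C1CCCN(Cc2ccc(F)cc2)C1`: 2250 nM
- compound 2 `O=C(Nc1ccc(-c2ccccc2)cc1)C1CCCN(Cc2ccc(F)c(F)c2)C1`: 2580 nM

In a functional assay on A-375 cells (Homo sapiens) for antiproliferative activity (on this read-out higher numbers stand for weaker inhibition and lower numbers for stronger inhibition), compound 1 gives 2250 nM and compound 2 gives 2580 nM. Compound 2 carries the higher of the two numbers shown, but its nearest neighbour, compound 1, sits within the scatter of it, so the two values show no real separation between them.

Compound 3 `O=C(Nc1ccc(-c2ccc[nH]2)cc1)C1CCCN(Cc2ccc(F)c(F)c2)C1` has not been measured in this assay. Relative to compound 2 the change is 1H-pyrrol-2-yl in place of phenyl on an aromatic carbon. Within the data shown here, no step between measured compounds bears on this kind of change, since compound 1 and compound 2 differ in more than one place and no single-point step exists in the set. With nothing beyond two values at about the same level to lean on, the expectation for the step in this assay is a small one, in no firm direction, and not beyond the scatter. For compound 3 the expected value in this assay is 2500 nM, with a range from 1000 nM to 6500 nM. That estimate corresponds to a step of a 1.0-fold lower number from compound 2 to compound 3 (0.01 log units; within the scatter), expected to stay within the usual scatter.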

Compound 3, half-maximal inhibitory concentration: 360 nM
Compound 3: the middle estimate sits 6.9-fold (0.84 log units) above what was measured; the measured number lies below the stated range.
By their numbers in this assay, from the lowest: compound 3; then compounds 1 and 2 (each within the scatter of the next).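

In this assay, among these compounds, this position, an aromatic carbon para to a large group, is the first place where a single change moves the number beyond the scatter: 1H-pyrrol-2-yl in place of phenyl gives a 7.2-fold lower number from compound 2 to compound 3 (0.86 log units; beyond the scatter). The two earlier compounds sat at one level and gave no sign that this group mattered, but the step shows that the read-out is sensitive to what stands here. The step changes several things at once, a six-membered aromatic ring of carbon only giving way to a five-membered aromatic ring with a hetero atom and a hydrogen-bond donor entering, and no data at hand separate these features or offer a reason for the step.

The compounds shown leave open whether the ring size, the ring nitrogen or its hydrogen carries the step, a question that 1-methylpyrrol-2-yl, furan-2-yl and thiophen-2-yl at the same carbon would address. Also open, going by these compounds, is whether the step holds when the rest of the molecule changes, with a single-fluorine benzyl group as one example.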